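Will Butyl Move Compound 3 in Cell Testing?

The source may report more compounds than this note shows. Statements on the series, on what has been measured and on what is new or still open speak of the compounds shown alone.

Going by the values given here, in a functional assay on KKU-M214 cells (Homo sapiens) for cytotoxicity (on this read-out lower numbers stand for stronger inhibition and higher numbers for weaker inhibition), compound 3 `C[C@H]1C(=O)/C=C/C(C)(C)C[C@@H]2O[C@]2(C)CC[C@H]1N` gives 18300 nM, the lowest number so far and beyond the scatter of both neighbours: compound 2 `CCCCN[C@@H]1CC/C(C)=C/CC(C)(C)/C=C/C(=O)[C@@H]1C` gives 41600 nM and compound 1 `C/C1=C\CC(C)(C)/C=C/C(=O)[C@H](C)[C@H](N)CC1` gives 59700 nM. Compound 4 `CCCCN[C@@H]1CC[C@@]2(C)O[C@H]2CC(C)(C)/C=C/C(=O)[C@@H]1C` differs from compound 3 by butyl in place of hydrogen on an amine nitrogen. One measured step makes the same swap, on the core of compound 1: a 1.4-fold lower number from compound 1 to compound 2 (0.16 log units; within the scatter), which lies within the scatter. With this single precedent, no clear step is expected in this assay. The expected change is a 1.3-fold lower number from compound 3 to compound 4 (0.12 log units; within the scatter), also within the scatter. For compound 4 the estimate is 14000 nM, with an expected range of 6500 nM to 30000 nM.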

Compound 4, half-maximal inhibitory concentration: 51000 nM
Beside the measured number, compound 4's estimate is 3.6-fold (0.56 log units) below it; measured number outside the range, above it.
By their numbers in this assay, from the lowest: compound 3; then compounds 2, 4 and 1 (each within the scatter of the next).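

In this assay butyl in place of hydrogen on an amine nitrogen gives a 2.8-fold higher number from compound 3 to compound 4 (0.45 log units; beyond the scatter) and so makes a clear difference on this core. This shows that the same swap at this nitrogen need not carry the same result from one core to another. The two steps do not agree: the same change on two cores in this assay, a 1.4-fold lower number (0.16 log units; within the scatter) from compound 1 to compound 2 and a 2.8-fold higher number (0.45 log units; beyond the scatter) from compound 3 to compound 4, 4.0-fold (0.60 log units) apart, beyond the scatter of two such steps

On these data alone, whether a shorter chain such as methyl, or a benzyl group, on this nitrogen would follow the course of compound 2 or that of compound 4 stays open. As far as these compounds go, what in the two cores sets the steps apart also stays open.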